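Methoxy added to the aryl tail of compound 2

The compounds below may be only part of what the source reports. "The series", "measured", "known", "first", "only" and "open" are said of these compounds alone.

Measured compounds:
compound 1, `COc1ccc(CCc2nc(N)c3nn(-c4ccccc4)cc3n2)cc1`, 22%
compound 2, `Nc1nc(CCCc2ccccc2)nc2cn(-c3ccccc3)nc12`, 12%

Both were tested in an assay on CHO cells for displacement of a labelled ligand from adenosine receptor A3 (Homo sapiens), read by scintillation counting, tested at 1 uM; a higher number here means more inhibition at the concentration tested (going by the name of the read-out), a lower number less inhibition. Going by the values given here, compound 2 gives 12%, and the only measured step connecting it to another compound is a number 10 percentage points lower from compound 1 to compound 2 (within the scatter), which replaces 4-methoxyphenyl with benzyl on the saturated chain and lies within the scatter. Compound 3, `COc1cccc(CCCc2nc(N)c3nn(-c4ccccc4)cc3n2)c1`, has not been measured. It differs from compound 2 by methoxy in place of hydrogen on an aromatic carbon; the group enters on an aromatic carbon of a six-membered aromatic ring of carbon only, so that benzyl becomes 3-methoxybenzyl.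

Among the compounds with values here, the one step that bears on this change is a number 10 percentage points lower from compound 1 to compound 2 (within the scatter): removing a methoxy from the aryl tail, there from a different ring carbon, moved the number by no more than the scatter. Putting a methoxy back, now meta to a large group, is therefore expected to give a step of a number 5 percentage points higher from compound 2 to compound 3 (within the scatter) in this assay, with no movement beyond the scatter in either direction. Compound 3 is estimated at 17%, between 4% and 32%.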

Compound 3, a percentage reported as inhibition, at one concentration (the size of the read-out at that concentration, not a potency): 33%
For compound 3 the middle estimate is 16 percentage points below the measured one, outside the stated range (above it).
By their numbers in this assay, from the lowest: compounds 2 and 1 (each within the scatter of the next); then compound 3.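

In this assay, methoxy in place of hydrogen on an aromatic carbon, meta to a large group, gives a number 21 percentage points higher from compound 2 to compound 3 (beyond the scatter), so this change on the benzyl tail moves the number beyond the scatter, which the earlier step, a number 10 percentage points lower from compound 1 to compound 2 (within the scatter), did not show. Setting 3-methoxybenzyl in place of 4-methoxyphenyl on the saturated chain gives a number 11 percentage points higher from compound 1 to compound 3 (beyond the scatter), a modest step that shows that carrying a methoxy on the tail does not by itself fix the number, since these two methoxy-bearing tails differ beyond the scatter. Nothing presented here accounts for either step.

From the compounds shown here alone, what stays open is whether the rise is particular to methoxy or would also follow a hydroxyl, a chlorine or a methyl on the same carbon, and whether a methoxy on another carbon of this ring would give a similar step. All these readings come from one concentration, so they give the size of the inhibition at that concentration and leave the potency of compound 3 open.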